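The source may report more compounds than this note shows. Statements on the series, on what has been measured and on what is new or still open speak of the compounds shown alone.

Measured compounds: compound 1 `Cc1cc(C)cc(NC(=O)CN2CCC(c3cccc[n+]3[O-])CC2)c1` gives 76% in a functional assay on HEK293 cells for agonist activity at D(4) dopamine receptor (Homo sapiens), read by FLIPR; on this read-out lower numbers stand for smaller maximal responses and higher numbers for larger maximal responses; compound 2 `O=C(CN1CCC(c2cccc[n+]2[O-])CC1)Nc1cccc(F)c1` gives 70% in this assay.

Compound 2 stands lowest of the two numbers, though its gap to compound 1, a number 6 percentage points lower from compound 1 to compound 2 (within the scatter), lies within the scatter. Compound 3 `O=C(CN1CCC(c2cccc[n+]2[O-])CC1)NC1CCCCC1` differs from compound 2 by cyclohexyl in place of 3-fluorophenyl on an amide-type nitrogen. Among the compounds with values here, the only measured step swaps one aromatic ring for another and changed little; a switch to a non-aromatic ring has no precedent here, so the expectation rests on a wide range. A modest drop is expected, a number 12 percentage points lower from compound 2 to compound 3 (beyond the scatter), and compound 3 is estimated at 58% (30% to 85%).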

Compound 3, largest response reached (reported as efficacy), in percent of the reference or control that the assay uses: 58%
The estimate for compound 3 equals the measured number at the digits printed, within the range that was stated.
By their numbers in this assay, from the lowest: compound 3; then compounds 2 and 1 (each within the scatter of the next).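

In this assay the amide-type nitrogen proves sensitive to the kind of ring it carries. Cyclohexyl gives a number 12 percentage points lower from compound 2 to compound 3 (beyond the scatter) and also a number 18 percentage points lower from compound 1 to compound 3 (beyond the scatter) in place of the 3,5-dimethylphenyl, so both steps from an aromatic ring to a non-aromatic one exceed the scatter, whereas the one swap between aromatic rings did not.

Nothing given here explains this drop. Going by these compounds, whether a benzyl group or an open butyl chain on this nitrogen would read closer to compound 3 or to the aromatic compounds remains open.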